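A few compounds are considered here, and "the series" means these few. Any claim that something is new, unique, unknown or untested is made for them only; others in the source may bear on it.

Working notes on the series: the core stays fixed and only the hydroxylated chain on the amino nitrogen varies. In a functional assay on A2780 cells (Homo sapiens) for inhibition, read by sulforhodamine B assay, with a stated time of 96 h (a higher number here means a weaker inhibitor of growth, a lower number a stronger inhibitor of growth), compound 1 (`CC[C@@H](Nc1nc(NCc2ccccn2)c2ncn(C(C)C)c2n1)C(C)O`) gives 27000 nM, compound 2 (`CC[C@H](Nc1nc(NCc2ccccn2)c2ncn(C(C)C)c2n1)C(C)O`) gives 17000 nM and compound 3 (`CC[C@H](Nc1nc(NCc2ccccn2)c2ncn(C(C)C)c2n1)C(C)(C)O`) gives 44000 nM. Compound 3 thus lies within the scatter of compound 1 and beyond the scatter above compound 2, though only modestly.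

Compound 4 (`CC[C@H](Nc1nc(NCc2ccccn2)c2ncn(C(C)C)c2n1)C(O)C(C)(C)C`) has not yet been measured. Its difference from compound 3 is 1-hydroxy-2,2-dimethylpropyl in place of 1-hydroxy-1-methylethyl on a saturated chain carbon bound to a nitrogen on an aromatic ring and a saturated chain carbon. Cut one bond further out, 1-(1-hydroxy-1-methylethyl)propyl becomes 1-ethyl-2-hydroxy-3,3-dimethylbutyl.

Among the measured compounds shown here, three measured steps bear on this change, all in the same chain. The largest, a 2.6-fold higher number from compound 2 to compound 3 (0.41 log units; beyond the scatter), is a single added methyl and is modest. The others, a 1.6-fold higher number from compound 1 to compound 3 (0.21 log units; within the scatter) and a 1.6-fold lower number from compound 1 to compound 2 (0.20 log units; within the scatter), stay within the scatter. For the measured compounds named here, no measured compound carries the 1-hydroxy-2,2-dimethylpropyl group, so these steps fix no direction, and they give only a small size for changes in this chain.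

In this assay the expected step is a 1.3-fold lower number from compound 3 to compound 4 (0.10 log units; within the scatter), which is none beyond the scatter. The estimate for compound 4 is 35000 nM, with an expected range of 13000 nM to 90000 nM.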

Compound 4, concentration for 50% growth inhibition: > 50000 nM
Compound 4 gave a limit, no number; the forecaster's own chance of this, stated with the estimate: 15%; at least 1.4-fold (0.15 log units) between middle value and limit.
By their numbers in this assay, from the lowest: compounds 2, 1 and 3 (each within the scatter of the next, the first and the last beyond it). At a limit, above all of these: compound 4.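

In this assay compound 4 gives > 50000 nM, which is a limit of the assay and not a number. Among the compounds shown here, the only new step that clears the scatter is an at least 2.9-fold higher number from compound 2 to compound 4 (0.46 log units; beyond the scatter), while an at least 1.1-fold higher number from compound 3 to compound 4 (0.05 log units; that floor lies within the scatter) and an at least 1.8-fold higher number from compound 1 to compound 4 (0.26 log units; that floor lies within the scatter) have floors within the scatter, so the size of these two steps remains unfixed. The earlier compounds shown here fixed no direction for this change, and 1-hydroxy-2,2-dimethylpropyl in place of 1-hydroxy-1-methylethyl on this saturated chain carbon now gives no sign of a lower number.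

Going by these compounds, how far the true value of compound 4 lies from its limit remains open, and the comparison with compound 3 cannot be settled from a floor within the scatter. Also open, on these data alone, is whether an amine or a carboxylic acid in place of the hydroxyl group, or a shorter chain on this carbon, would give a lower number in this assay.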